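This account rests on a few compounds, and the source may have more. Where it says the series, first, only, none or still open, it means among the compounds named here.

Values in a physicochemical assay for lipophilicity (a lower number here means a more polar compound, a higher number a more lipophilic compound), so far:
- compound 1 `CC(C)Oc1cc(Oc2ccc(C(=O)N3CCC3)cc2)cc(C(=O)Nc2ccn(C)n2)c1` gives 3.3
- compound 2 `COC[C@H](C)Oc1cc(Oc2ncc(C(=O)N3CCC3)cc2Cl)cc(C(=O)Nc2cnc(C)cn2)c1` gives 2.8

Compound 1 holds the higher of the two numbers, and compound 2 lies lower by a gap beyond the scatter. The change to compound 3 `C[C@@H](CO)Oc1cc(Oc2ccc(C(=O)N3CCC3)cc2)cc(C(=O)Nc2ccn(C)n2)c1` is hydroxy in place of hydrogen on a saturated chain carbon, two bonds along the chain from an oxygen on an aromatic ring and reads isopropoxy to 1-(hydroxymethyl)ethoxy. For the measured compounds named here, no measured pair shows this change, so the expectation rests on the structural change alone: a fall in this assay beyond the scatter. The estimated size is a number 0.90 log units lower from compound 1 to compound 3 (beyond the scatter) as expected here. Compound 3 is expected at 2.4 within an estimated range of 2 to 2.8.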

Compound 3, distribution coefficient: 1.8
Beside the measured number, compound 3's estimate is 0.60 log units above it; measured number outside the range, below it.
By their numbers in this assay, from the lowest: compound 3; then compound 2; then compound 1.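

Hydroxy in place of hydrogen on a saturated chain carbon, two bonds along the chain from an oxygen on an aromatic ring, gives in this assay a number 1.50 log units lower from compound 1 to compound 3 (beyond the scatter) as a large step. For the compounds shown here, this is the first pair differing in one place, and it shows that this chain position, reading isopropoxy to 1-(hydroxymethyl)ethoxy, responds strongly with the rest of compound 1 unchanged. No measured evidence here bears on the size of this step. As far as these compounds go, whether a methoxy, an amine or a carboxylic acid at this position would give a similar step remains open.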